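This account rests on a few compounds, and the source may have more. Where it says the series, first, only, none or still open, it means among the compounds named here.

Measured in a functional assay on IMR-32 cells (Homo sapiens) for cytotoxicity, read by sulforhodamine B assay, with a stated time of 48 h; a higher number here means a weaker inhibitor, a lower number a stronger inhibitor:
compound 1 `CC1=C(/C=C/C(=O)/C=C/c2ccccc2)C(C)(C)CCC1` gives 20400 nM
compound 2 `CC1=C(/C=C/C(=O)/C=C/c2ccccc2Cl)C(C)(C)CCC1` gives 13700 nM
compound 3 `COc1ccccc1/C=C/C(=O)/C=C/C1=C(C)CCCC1(C)C` gives 19200 nM

Compound 3 stands second highest of these three numbers, nearest to compound 1 and furthest from compound 2, although a 1.1-fold lower number from compound 1 to compound 3 (0.03 log units; within the scatter) and a 1.4-fold higher number from compound 2 to compound 3 (0.15 log units; within the scatter). Compound 4 `CC1=C(/C=C/C(=O)/C=C/c2ccccc2[N+](=O)[O-])C(C)(C)CCC1` differs from compound 3 by nitro in place of methoxy on an aromatic carbon. Every measured step touches the same aromatic carbon with a different group: a 1.5-fold lower number from compound 1 to compound 2 (0.17 log units; within the scatter), a 1.1-fold lower number from compound 1 to compound 3 (0.03 log units; within the scatter), a 1.4-fold higher number from compound 2 to compound 3 (0.15 log units; within the scatter). None moved the number beyond the scatter, so no step beyond the scatter is expected in this assay for the nitro group either. Compound 4 is therefore estimated at 15000 nM, with a range from 7000 nM to 32000 nM. This expectation amounts to a 1.3-fold lower number from compound 3 to compound 4 (0.11 log units; within the scatter).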

Compound 4, half-maximal inhibitory concentration: 13500 nM
Beside the measured number, compound 4's estimate is 1.1-fold (0.05 log units) above it; measured number inside the range.
By their numbers in this assay, from the lowest: compounds 4, 2, 3 and 1 (each within the scatter of the next).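

In this assay, the nitro group on this aromatic carbon, ortho to a large group, produced no step beyond the scatter: a 1.4-fold lower number from compound 3 to compound 4 (0.15 log units; within the scatter), a 1.0-fold lower number from compound 2 to compound 4 (0.01 log units; within the scatter) and a 1.5-fold lower number from compound 1 to compound 4 (0.18 log units; within the scatter). Hydrogen, chloro, methoxy and nitro at this position therefore all lie within the scatter of one another in compounds 1, 2, 3 and 4. No measurement shown offers an explanation for this result.

Going by these compounds, whether an amine or a carboxylic acid on this aromatic carbon would also stay within the scatter remains open. So does whether a change elsewhere on the shared core would move the number.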